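This account rests on a few compounds, and the source may have more. Where it says the series, first, only, none or still open, it means among the compounds named here.

Going by the values given here, compound 1 `CCc1ccc(NC2=CC(=O)c3nc4n(c3C2=O)[C@H]2OC[C@@H](O)[C@H]2OC4)cc1` is the only member with a number in a functional assay on HeLa cells (Homo sapiens) for inhibition, read by sulforhodamine B assay (a higher number here means a weaker inhibitor, a lower number a stronger inhibitor), where compound 1 gives 3990 nM. Compound 2 `O=C1C(N2CCC2)=CC(=O)c2c1nc1n2[C@H]2OC[C@@H](O)[C@H]2OC1` reaches only a limit in this assay, with compound 2 at > 16000 nM; this is the limit of > 16000 nM in this assay, at which 1 of the 2 values shown sits. Compound 3 `O=C1C=C(Nc2ccccc2F)C(=O)c2c1nc1n2[C@H]2OC[C@@H](O)[C@H]2OC1` is not yet measured and differs from compound 1 by 2-fluorophenyl in place of 4-ethylphenyl on an amine nitrogen. Among the compounds with values here, no measured pair shows this change, so its size is open; the expectation is a small shift toward weaker inhibition, a 1.5-fold higher number from compound 1 to compound 3 (0.18 log units; within the scatter), within or just beyond the usual scatter. Compound 3 is accordingly expected to give 6000 nM in this assay, with a range from 2000 nM to 18000 nM.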

Compound 3, half-maximal inhibitory concentration: 5120 nM
Compound 3: the middle estimate sits 1.2-fold (0.07 log units) above what was measured, within the range that was stated.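

Placing 2-fluorophenyl in place of 4-ethylphenyl on an amine nitrogen gives a 1.3-fold higher number from compound 1 to compound 3 (0.11 log units; within the scatter) in this assay, so the two aryl groups are not told apart at this position. The step replaces the ethyl group with fluorine and alters where the substituent stands on the ring, so it cannot assign a separate contribution to either. Nothing available accounts for the size of this step.

Still open, going by these compounds, is how an unsubstituted phenyl, a benzyl group or a longer alkyl chain on this nitrogen would read.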